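The compounds below may be only part of what the source reports. "The series", "measured", "known", "first", "only" and "open" are said of these compounds alone.

Measured so far:
- compound 1 `O=C1C[C@@H](O)[C@@H](C2=CC(=O)c3ccccc3C2=O)O1` — 2940 nM in an assay on isolated protein for inhibition of RAC-alpha serine/threonine-protein kinase (Homo sapiens), read by FRET and Z'-LYTE, with a stated time of 1 h; a higher number here means a weaker inhibitor, a lower number a stronger inhibitor
- compound 2 `COC/C=C/C(=O)c1ccccc1` — 50000 nM in this assay

Compound 2 stands at the highest of the two numbers; compound 1 sits well below it, a gap beyond the usual scatter. Compound 3 `COC(=O)CC/C=C/C(=O)c1ccccc1` differs from compound 2 by (methoxycarbonyl)methyl in place of methoxy on a saturated chain carbon bound to a double-bonded chain carbon. Within the data shown here, no step between measured compounds covers such a change, so nothing here supports a clear direction; the expectation is a change of no more than the scatter, with the step from compound 2 expected as a 1.3-fold lower number from compound 2 to compound 3 (0.10 log units; within the scatter). Compound 3 is therefore expected near 40000 nM, between 10000 nM and 150000 nM.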

Compound 3, half-maximal inhibitory concentration: 13700 nM
Compound 3: middle estimate off by 2.9-fold (0.47 log units), on the high side; the measured number falls inside the stated range.
By their numbers in this assay, from the lowest: compound 1; then compound 3; then compound 2.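

Among these compounds, on a saturated chain carbon bound to a double-bonded chain carbon, (methoxycarbonyl)methyl in place of methoxy gives a 3.6-fold lower number from compound 2 to compound 3 (0.56 log units; beyond the scatter) in this assay and so shows that this position responds to a change of group, which no earlier pair could show. The step is modest and rests on this single pair. No measured property bears on the reason for the shift. Still open, as far as these compounds go, is whether the methoxycarbonyl group or the added chain length carries the step: a carboxylic acid, an amide or a plain propyl chain at this place would separate the two.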